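A few compounds are considered here, and "the series" means these few. Any claim that something is new, unique, unknown or untested is made for them only; others in the source may bear on it.

Of the compounds shown here, two sharing one core have been measured in a functional assay on U-937 cells (Homo sapiens) for antiproliferative activity, read by CCK-8 assay, with a stated time of 24 h; a higher number here means a weaker inhibitor, a lower number a stronger inhibitor. Compound 1 `CCN(CC)Cc1ccc2nc(NC(=O)N/N=C(\C)c3ccccn3)sc2c1`, which carries pyridin-2-yl, gives 15600 nM. Compound 2 `CCN(CC)Cc1ccc2nc(NC(=O)N/N=C(\C)c3cnccn3)sc2c1` has no number, only a limit of the assay, > 40000 nM. Its true standing is therefore open. The next compound, compound 3 `CCN(CC)Cc1ccc2nc(NC(=O)N/N=C(\C)c3ccc(F)cc3)sc2c1`, changes the same place again: 4-fluorophenyl in place of pyrazin-2-yl on a carbon with a double bond to nitrogen. Here 4-fluorophenyl stands in place of pyrazin-2-yl on a carbon with a double bond to nitrogen. Among the compounds with values here, only one measured step bears on this change: an at least 2.5-fold higher number from compound 1 to compound 2 (0.40 log units; beyond the scatter), which put pyrazin-2-yl in place of pyridin-2-yl at that same place. It shows that the group there can shift the number, but its size is known only as a bound, and neither measured compound has a ring of carbon only there. The expectation therefore rests on compound 1 at 15600 nM, and a return to about that level is expected, a modest move towards stronger inhibition in this assay. The estimated change is an at least 2.8-fold lower number from compound 2 to compound 3 (0.45 log units; beyond the scatter). For compound 3 the expected value is 14000 nM, with an estimated range of 5000 nM to 38000 nM.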

Compound 3, half-maximal inhibitory concentration: > 40000 nM
Compound 3 ended at the assay's limit; the forecaster's own chance of this, stated with the estimate: 20%; middle value at least 2.8-fold (0.45 log units) away from the limit.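

Exchanging pyridin-2-yl for 4-fluorophenyl gives an at least 2.5-fold higher number from compound 1 to compound 3 (0.40 log units; beyond the scatter) in this assay, so a ring of carbon only at this place does not bring back the level of compound 1. Pyrazin-2-yl, a ring with 2 hetero atoms, and 4-fluorophenyl, a ring of carbon only, both leave a weaker result than pyridin-2-yl, and among the compounds shown only compound 1 gives a readable value at this place: the limit of > 40000 nM in this assay, at which 2 of the 3 values shown sit. Compound 2 and compound 3 both stand at a limit of the assay rather than at a number, and the step between them cannot be read.

From the compounds shown here alone, how far each of the two replacements lies from compound 1, and which of them is the weaker, stays open. Also open, going by these compounds, is whether another group at this place, such as pyridin-3-yl, unsubstituted phenyl or a piperidine ring, would match compound 1 or exceed it in this assay.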